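From Fluoro to a Selenium-Bearing Chain on the Shared Core

The source may hold more compounds than are shown below. What is called first, only, known or untested is meant among the compounds shown, and "the series" means these compounds.

Compound 1 `COc1ccc(N(C)c2ccnc(Cl)n2)cc1F`: in a functional assay on HepG2 cells (Homo sapiens) for antiproliferative activity, read by MTT assay, with a stated time of 48 h (on this read-out higher numbers stand for weaker inhibition and lower numbers for stronger inhibition), compound 1 gives 844 nM
Compound 2 `COc1ccc(N(C)c2ccnc(Cl)n2)cc1OCCCCBr`: in this assay compound 2 gives 168 nM

Compound 1 has the highest of the two numbers. For the measured compounds named here, the only measured step, a 5.0-fold lower number from compound 1 to compound 2 (0.70 log units; beyond the scatter), placed a chain on the same aromatic carbon and is the one precedent for compound 3 `COc1ccc(N(C)c2ccnc(Cl)n2)cc1OCCCC[Se]C#N`, which differs from compound 1 by a group of 8 heavy atoms (5 carbon, 1 nitrogen, 1 oxygen, 1 selenium; no ring) in place of one fluorine atom, on an aromatic carbon. A step of similar size and direction is therefore expected in this assay. For compound 3 the estimate is 200 nM, between 70 nM and 600 nM, which would mean a 4.2-fold lower number from compound 1 to compound 3 (0.63 log units; beyond the scatter).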

Compound 3, half-maximal inhibitory concentration: > 10000 nM
Compound 3: a limit, no number (the forecaster's own chance of this, stated with the estimate: 2%); at least 50-fold (1.69 log units) between middle value and limit.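

In this assay compound 3 has a limit, not a number: the limit of > 10000 nM in this assay, at which 1 of the 3 values shown sits. A chain on this aromatic carbon does not in itself bring a lower number: the selenium-bearing chain gives an at least 11-fold higher number from compound 1 to compound 3 (1.07 log units; beyond the scatter), opposite in direction to a 5.0-fold lower number from compound 1 to compound 2 (0.70 log units; beyond the scatter). At the far end of the chain, with the rest of the structure unchanged, the group that replaces bromine gives an at least 59-fold higher number from compound 2 to compound 3 (1.77 log units; beyond the scatter), so this position tolerates one chain end and not the other. The compounds shown leave open whether a chain ending in an amine or a carboxylic acid would behave like compound 2 or like compound 3, and whether a longer chain would shift either result.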